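From pyrimidin-2-yl to 1,3-thiazol-2-yl on a sulfonamide

A few compounds are considered here, and "the series" means these few. Any claim that something is new, unique, unknown or untested is made for them only; others in the source may bear on it.

Compound 1 `Cc1cc(C)nc(NS(=O)(=O)c2ccc(Nc3nncc4ccccc34)cc2)n1`: 3.3 nM
Compound 2 `S=C(NNc1nncc2ccccc12)Nc1ccccc1`: 40 nM
Compound 3 `O=S(=O)(Nc1ncccn1)c1ccc(Nc2nncc3ccccc23)cc1`: 29 nM

All three values come from a functional assay on HT-29 cells (Homo sapiens) for antiproliferative activity, read by sulforhodamine B assay, with a stated time of 72 h; a higher number here means a weaker inhibitor, a lower number a stronger inhibitor. In this assay, compound 3 lies within the usual scatter of compound 2, while its gap to compound 1 is clearly beyond the scatter.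

Compound 4 `O=S(=O)(Nc1nccs1)c1ccc(Nc2nncc3ccccc23)cc1` differs from compound 3 in one place, on a sulfonamide nitrogen, where 1,3-thiazol-2-yl takes the place of pyrimidin-2-yl: 1,3-thiazol-2-yl in place of pyrimidin-2-yl on a sulfonamide nitrogen.

Going by the values given here, only one measured step involves this same nitrogen. Pyrimidin-2-yl in place of 4,6-dimethylpyrimidin-2-yl gave an 8.8-fold higher number from compound 1 to compound 3 (0.94 log units; beyond the scatter), a modest step. It shows that a change here can shift the number, but it is a different change and gives no direction for this swap. Among the compounds with values here, no measured compound carries 1,3-thiazol-2-yl, so the expectation is uncertain.

The expected result in this assay is no step beyond the scatter, with neither direction favoured: no change at the digits printed from compound 3 to compound 4 (within the scatter). Compound 4 is estimated at 29 nM, with an expected range of 8 nM to 100 nM.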

Compound 4, half-maximal inhibitory concentration: 34 nM
The estimate for compound 4 lay 1.2-fold (0.07 log units) below the measured number; measured number inside the range.
By their numbers in this assay, from the lowest: compound 1; then compounds 3, 4 and 2 (each within the scatter of the next).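

In this assay, replacing the six-membered pyrimidin-2-yl with the five-membered 1,3-thiazol-2-yl on the sulfonamide nitrogen gives a 1.2-fold higher number from compound 3 to compound 4 (0.07 log units; within the scatter), so a different ring size and a ring sulfur can be accepted here without a readable change in the number. The large step is instead a 10-fold higher number from compound 1 to compound 4 (1.01 log units; beyond the scatter), which places compound 1, with its 4,6-dimethylpyrimidin-2-yl group, clearly apart from compound 4, as it already stood apart from compound 3. No measurement shown here explains these values.

Going by these compounds, it remains open whether a single methyl on the pyrimidine ring would be enough to give the low number of compound 1, and whether methyl groups on the 1,3-thiazole ring would have a similar effect. A non-aromatic group on this nitrogen, such as an acetyl or a short alkyl chain, is also untested among these compounds.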